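The compounds below may be only part of what the source reports. "The series", "measured", "known", "first", "only" and "open" are said of these compounds alone.

Within the data shown here, compound 2 `CC(C)(O/N=C(\C(=O)N[C@@H]1C(=O)N(S(=O)(=O)O)[C@@H]1Cn1cncn1)c1csc(N)n1)C(=O)O` gives 233 h in a physicochemical assay for metabolic stability, read by HPLC and mass spectrometry, in phosphate buffer, at 37 degrees C, at pH 7.4 (on this read-out lower numbers stand for a shorter-lived compound and higher numbers for a longer-lived compound), the lower of the two numbers so far; compound 1 `CC(C)(O/N=C(\C(=O)N[C@@H]1C(=O)N(S(=O)(=O)O)[C@@H]1Cn1ccnn1)c1csc(N)n1)C(=O)O` gives 257 h, and the single measured step is a 1.1-fold lower number from compound 1 to compound 2 (0.04 log units; within the scatter). Compound 3 `CC(C)(O/N=C(\C(=O)N[C@@H]1C(=O)N(S(=O)(=O)O)[C@@H]1Cn1ncnc1CN)c1csc(N)n1)C(=O)O` differs from compound 2 by aminomethyl in place of hydrogen on an aromatic carbon. That measured step exchanges the ring itself rather than adding a group on an aromatic carbon, so it bears only loosely on this change, and it stayed within the scatter. Expected for compound 3 is therefore a 1.2-fold lower number from compound 2 to compound 3 (0.07 log units; within the scatter), nothing beyond the scatter. Compound 3 is estimated at 200 h, range 100 h to 400 h.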

Compound 3, half-life: > 37 h
Compound 3 ended at the assay's limit; the forecaster's own chance of this, stated with the estimate: 5%; the middle value does not contradict the limit.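

In this assay compound 3 gives > 37 h, a limit of the assay and not a number, so the steps from compound 1 and compound 2 to compound 3 cannot be read. Still open, from the compounds shown here alone, is how far aminomethyl in place of hydrogen on an aromatic carbon shifts the half-life.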